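Replacing the Trifluoromethylphenyl Arm by Naphthalen-1-yl

This account rests on a few compounds, and the source may have more. Where it says the series, first, only, none or still open, it means among the compounds named here.

Compound 1 `Nc1scc(CN2CCN(c3cccc(C(F)(F)F)c3)CC2)c1C(=O)c1ccc(Cl)cc1` stands lowest of the two measured numbers in a functional assay on CHO cells with adenosine receptor A1 (Homo sapiens) as the target, read by cAMP accumulation and immunoassay, with a stated time of 6 min, tested at 1 uM; a lower number here means a stronger effect, a higher number a weaker effect of the compound at the concentration tested: in that assay compound 1 gives -72%. Compound 2 `Nc1scc(CN2CCN(c3c(F)cccc3F)CC2)c1C(=O)c1cccc(C(F)(F)F)c1` differs from it in two places at once, and in this assay compound 2 gives 1.3%, a number far higher than that of compound 1 and beyond the scatter. Among the compounds with values here, two changes are made together, so no single step between measured compounds is available. Within the data shown here, the two values show only that the arrangement of compound 1 carries the strong effect while that of compound 2 carries essentially none.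

Compound 3 `Nc1scc(CN2CCN(c3cccc4ccccc34)CC2)c1C(=O)c1ccc(Cl)cc1` keeps everything of compound 1 except for one change: naphthalen-1-yl in place of 3-(trifluoromethyl)phenyl on an amine nitrogen in a ring. One six-membered aromatic ring of carbon bearing a trifluoromethyl group gives way to two six-membered aromatic rings of carbon, with no change in donors, acceptors or charge.

Among the measured compounds shown here, with no measured step to lean on, the author expects the step of a number 27 percentage points higher from compound 1 to compound 3 (beyond the scatter) to go toward a higher number, probably beyond the scatter, while much of the effect of compound 1 is kept. Compound 3 is therefore estimated at -45% in this assay, within a range from -90% to 5%.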

Compound 3, a percentage reported as activity, at one concentration (the size of the read-out at that concentration, not a potency): 2.9%
Compound 3: the middle estimate sits 47.9 percentage points below what was measured; the measured number falls inside the stated range.
By their numbers in this assay, from the lowest: compound 1; then compounds 2 and 3 (each within the scatter of the next).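

In this assay, within the data shown here, the single change of naphthalen-1-yl in place of 3-(trifluoromethyl)phenyl on an amine nitrogen in a ring gives a large step, a number 74.9 percentage points higher from compound 1 to compound 3 (beyond the scatter), with the rest of compound 1 held fixed. The earlier pair differed in two places at once and could not tie the loss of effect to any one of them, whereas this step shows that the group at this position can by itself decide whether the strong effect of compound 1 is seen, even though the heavy-atom count, the hydrogen-bond donors and acceptors and the net charge of the group stay the same. Nothing available here explains why this exchange has so large an effect.

As far as these compounds go, it remains open whether a plain phenyl, a phenyl bearing a chlorine or a methoxy group, or a pyridine ring on the same nitrogen would keep the effect of compound 1 or lose it as naphthalen-1-yl does. From the compounds shown here alone, it also remains open how much each of the two changes that separate compound 2 from compound 1 contributes on its own.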